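A few compounds are considered here, and "the series" means these few. Any claim that something is new, unique, unknown or untested is made for them only; others in the source may bear on it.

Compound 2 `Nc1nc(N)c2c(Cl)c(Br)ccc2n1` gives 100 nM in an assay for inhibition of Dihydrofolate reductase (Rattus norvegicus) (a lower number here means a stronger inhibitor, a higher number a weaker inhibitor), the lowest of the two numbers recorded; the other, for compound 1 `Nc1nc(N)c2c(/C=C/c3ccc4ccccc4c3)cccc2n1`, is 3020 nM in this assay, a gap beyond the scatter. Compound 3 `Nc1nc(N)c2c(Cl)c(N)ccc2n1` is the next one to be measured, differing from compound 2 in a single place: amino in place of bromo on an aromatic carbon. Among the compounds with values here, no measured pair shows this same exchange, so its effect is unknown here. The step from compound 2 to compound 3 is expected to be modest and toward a higher number, as a 3.0-fold higher number from compound 2 to compound 3 (0.48 log units; beyond the scatter). For compound 3 the estimate is 300 nM in this assay, with a likely range from 80 nM to 1500 nM.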

Compound 3, half-maximal inhibitory concentration: 661 nM
Beside the measured number, compound 3's estimate is 2.2-fold (0.34 log units) below it; low and high end bracket the measured number.
By their numbers in this assay, from the lowest: compound 2; then compound 3; then compound 1.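

In this assay amino in place of bromo on an aromatic carbon ortho to a chloro group gives a 6.6-fold higher number from compound 2 to compound 3 (0.82 log units; beyond the scatter) and so shows that, on this core, the number responds to what this position carries. Bromo gives the stronger inhibitor of this single pair, which is too little to set a trend. Nothing measured here offers a reason for the step.

From the compounds shown here alone, it remains open whether fluoro, methyl or methoxy at this position would fall nearer bromo or amino. Also open, going by these compounds, is whether the exchange would have the same size without the chloro group.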